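Swapping the amide substituent on a shared core

The source may report more compounds than this note shows. Statements on the series, on what has been measured and on what is new or still open speak of the compounds shown alone.

Values in a functional assay on PC-3 cells (Homo sapiens) for antiproliferative activity, read by MTT assay, with a stated time of 24 h; on this read-out lower numbers stand for stronger inhibition and higher numbers for weaker inhibition:
compound 1 `CCn1c(C(=O)NCCC(=O)OC)ccc1C(CC)(CC)c1ccc(OCS(=O)(=O)c2ccccc2)c(C)c1`: 40400 nM
compound 2 `CCn1c(C(=O)NC(C)(C)CO)ccc1C(CC)(CC)c1ccc(OCS(=O)(=O)c2ccccc2)c(C)c1`: 9850 nM
compound 3 `CCn1c(C(=O)N[C@@H](CO)CCO)ccc1C(CC)(CC)c1ccc(OCS(=O)(=O)c2ccccc2)c(C)c1`: 14100 nM
compound 4 `CCn1c(C(=O)NC2(C(=O)O)CC2)ccc1C(CC)(CC)c1ccc(OCS(=O)(=O)c2ccccc2)c(C)c1`: not yet measured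

Compound 3 holds the middle place among the three numbers. The data show a 1.4-fold higher number from compound 2 to compound 3 (0.16 log units; within the scatter) and a 2.9-fold lower number from compound 1 to compound 3 (0.46 log units; beyond the scatter).

The next change is 1-carboxycyclopropyl in place of 3-hydroxy-1-(hydroxymethyl)propyl on an amide-type nitrogen. Within the data shown here, no measured step carries this exact change. The closest evidence is the other replacements on that nitrogen, which show a 4.1-fold lower number from compound 1 to compound 2 (0.61 log units; beyond the scatter) alongside the two steps above. On that basis, in this assay a step within the scatter or a modest one is expected, leaning towards a higher number. Among the measured compounds shown here, that lean rests on compound 1 40400 nM, the only compound here without a hydroxyl-bearing group and the one with the highest number. The expected change is a 1.4-fold higher number from compound 3 to compound 4 (0.15 log units; within the scatter). For compound 4 the estimated value is 20000 nM, with an expected range from 7000 nM to 55000 nM.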

Compound 4, half-maximal inhibitory concentration: 26300 nM
Compound 4: middle estimate off by 1.3-fold (0.12 log units), on the low side, and the stated range covers the measured number.
By their numbers in this assay, from the lowest: compounds 2, 3, 4 and 1 (each within the scatter of the next, the first and the last beyond it).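

In this assay, the 1-carboxycyclopropyl group separates from only one of the three earlier substituents: a 2.7-fold higher number from compound 2 to compound 4 (0.43 log units; beyond the scatter), while a 1.9-fold higher number from compound 3 to compound 4 (0.27 log units; within the scatter) and a 1.5-fold lower number from compound 1 to compound 4 (0.19 log units; within the scatter). The amide-type nitrogen therefore takes a carboxylic acid on a three-membered ring with no clear break from either the two hydroxyl groups of compound 3 or the methyl ester of compound 1, even though those two compounds lie beyond the scatter of each other. Nothing available explains these steps.

The ring and the carboxylic acid enter together in compound 4, so the compounds shown cannot assign the step from compound 2 to either of them. Going by these compounds, a plain cyclopropyl group, or a 1-aminocyclopropyl group, on the same nitrogen would bear on that question, and how an amine there would read out remains open.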